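Notes on the step from methylsulfonyl to acetamido

A few compounds are considered here, and "the series" means these few. Any claim that something is new, unique, unknown or untested is made for them only; others in the source may bear on it.

Compound 1 `O=S(=O)(Nc1cccc(CO)c1)c1ccc(-c2ccc(C(F)(F)F)cc2)cc1` gives 2500 nM in a functional assay on J774 cells (Mus musculus) for cytotoxicity, read by resazurin assay, with a stated time of 72 h; on this read-out higher numbers stand for weaker inhibition and lower numbers for stronger inhibition. Compound 2 `CN(C)c1ccc(-c2ccc(S(=O)(=O)Nc3cccc(CO)c3)cc2)cc1` reaches only the limit of this assay, > 5000 nM. Compound 3 `CS(=O)(=O)c1ccc(-c2ccc(S(=O)(=O)Nc3cccc(CO)c3)cc2)cc1` likewise gives only the limit, > 5000 nM. The steps of an at least 2.0-fold higher number from compound 1 to compound 2 (0.30 log units; that floor lies within the scatter) and an at least 2.0-fold higher number from compound 1 to compound 3 (0.30 log units; that floor lies within the scatter) are both set by the limit of > 5000 nM in this assay, at which 2 of the 3 values shown sit, and the step that the two limits leave unreadable from compound 2 to compound 3 cannot be sized. Compound 3 therefore stands at the limit, with one further value in this assay also a limit.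

Compound 4 `CC(=O)Nc1ccc(-c2ccc(S(=O)(=O)Nc3cccc(CO)c3)cc2)cc1` differs from compound 3 by acetamido in place of methylsulfonyl on an aromatic carbon. The measured steps bearing on this change are floors only, so no direction can be read from them. Compound 4 is expected to stay near the limit, estimated at 6000 nM within 3000 nM to 20000 nM, the expected step that the limit leaves unreadable from compound 3 to compound 4 being none beyond the scatter.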

Compound 4, half-maximal inhibitory concentration: > 5000 nM
Compound 4 gave a limit, no number (the forecaster's own chance of this, stated with the estimate: 70%); the middle value lies beyond the limit too.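

In this assay, acetamido now sits at the limit alongside dimethylamino and methylsulfonyl, so a third replacement of trifluoromethyl at this place, para to a large group, yields no number: the limit of > 5000 nM in this assay, at which 3 of the 4 values shown sit. Among the compounds shown here, the steps among compound 2, compound 3 and compound 4 cannot be read, and the only readable step for the new compound is an at least 2.0-fold higher number from compound 1 to compound 4 (0.30 log units; that floor lies within the scatter). Among these four, compound 1 alone has a number, 2500 nM.

As far as these compounds go, it remains open whether a chlorine or a methyl at this place would give a number in this read-out. From the compounds shown here alone, it is equally open whether a carboxylic acid or a longer chain would stay at the limit.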